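Amide ring substitution in a cholesterol transporter binder series

The source may hold more compounds than are shown below. What is called first, only, known or untested is meant among the compounds shown, and "the series" means these compounds.

Measured compounds:
compound 1 `CCc1nn(CC)c(C2CCN(C(=O)CN3CN(c4ccccc4)C4(CCN(C(=O)c5ccc(C6CCCCC6)cc5)CC4)C3=O)CC2)c1C` — "not determined" (no result reported)
compound 2 `O=C(CN1CN(c2ccccc2)C2(CCN(C(=O)c3ccc(C4CCCCC4)cc3)CC2)C1=O)N1CCCCC1` — 1100 nM

Among the compounds with values here, in an assay on HEK293 cells for displacement of a labelled ligand from NPC1-like intracellular cholesterol transporter 1 (Homo sapiens) (a higher number here means a weaker inhibitor, a lower number a stronger inhibitor), compound 2 gives 1100 nM, the only number so far. Compound 1 stands at "not determined" (no result reported), so it offers no comparison. Compound 3 `CC(C)(C)OC(=O)NC1CCN(C(=O)CN2CN(c3ccccc3)C3(CCN(C(=O)c4ccc(C5CCCCC5)cc4)CC3)C2=O)CC1` derives from compound 2 by (tert-butoxycarbonyl)amino in place of hydrogen on a saturated ring carbon. Within the data shown here, no step between two measured compounds is available, so this change has no precedent to lean on. A change of this kind is expected to fall within the usual scatter, without a clear direction, and the step from compound 2 to compound 3 is estimated at a 1.1-fold higher number from compound 2 to compound 3 (0.04 log units; within the scatter). Compound 3 is accordingly expected near 1200 nM, in a range from 400 nM to 3600 nM.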

Compound 3, half-maximal inhibitory concentration: 4800 nM
The estimate for compound 3 lay 4.0-fold (0.60 log units) below the measured number; measured number above the stated range.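

In this assay, the saturated ring carbon three ring bonds from the ring nitrogen responds to substitution: (tert-butoxycarbonyl)amino in place of hydrogen gives a 4.4-fold higher number from compound 2 to compound 3 (0.64 log units; beyond the scatter) and so a weaker inhibitor. Within the data shown here, this is the first readable step, and it shows that this large group is not tolerated without loss at this position. Nothing available on these compounds accounts for the shift.

Open, on these data alone, is whether the loss follows the whole (tert-butoxycarbonyl)amino group or only part of it. A free amine or a smaller acetamide on the same carbon would separate the two.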